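The source may report more compounds than this note shows. Statements on the series, on what has been measured and on what is new or still open speak of the compounds shown alone.

Compound 1 `CCN(CC)CCNC(=O)c1ccc(C(CC)(CC)c2ccc(OCC(=O)C(C)(C)C)c(C)c2)n1CC` is the strongest of the three measured compounds in a functional assay on PC-3 cells (Homo sapiens), read by MTT assay, with a stated time of 48 h (a higher number here means a weaker inhibitor, a lower number a stronger inhibitor), where compound 1 gives 30 nM. Compound 2 `CCn1c(C(=O)NCCN(C)C)ccc1C(CC)(CC)c1ccc(OCC(=O)C(C)(C)C)c(C)c1` gives 2300 nM in this assay, and compound 3 `CCn1c(C(=O)NCCCN(C)C)ccc1C(CC)(CC)c1ccc(OCC(O)C(C)(C)C)c(C)c1` gives 3100 nM; these two values lie within the scatter of each other. The change from compound 2 to compound 1 is diethylamino in place of dimethylamino on a saturated chain carbon, two bonds along the chain from an amide-type nitrogen, and it made the step of a 77-fold lower number from compound 2 to compound 1 (1.88 log units; beyond the scatter). The difference between the cores of compound 2 and compound 3 is not broken down here. Compound 4 `CCN(CC)CCCNC(=O)c1ccc(C(CC)(CC)c2ccc(OCC(O)C(C)(C)C)c(C)c2)n1CC` differs from compound 3 by diethylamino in place of dimethylamino on a saturated chain carbon, three bonds along the chain from an amide-type nitrogen; this is the same kind of change, but the place differs, three bonds along the chain from the amide-type nitrogen rather than two. Because of a 77-fold lower number from compound 2 to compound 1 (1.88 log units; beyond the scatter), the step of a 10-fold lower number from compound 3 to compound 4 (1.01 log units; beyond the scatter) is expected, though smaller, since the chain and the core differ from the measured pair. Compound 4 is expected to give 300 nM, estimated between 60 nM and 1500 nM.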

Compound 4, half-maximal inhibitory concentration: 2500 nM
For compound 4 the middle estimate is 8.3-fold (0.92 log units) below the measured one, and the stated range ends below it.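

Putting diethylamino in place of dimethylamino gives a 1.2-fold lower number from compound 3 to compound 4 (0.09 log units; within the scatter) in this assay. The large gain seen on one core therefore did not carry over to the other: the same change on two cores in this assay, a 77-fold lower number (1.88 log units; beyond the scatter) from compound 2 to compound 1 and a 1.2-fold lower number (0.09 log units; within the scatter) from compound 3 to compound 4, 62-fold (1.79 log units) apart, beyond the scatter of two such steps. The two pairs differ both in chain, 2-(diethylamino)ethyl against 3-(diethylamino)propyl, and in a carbonyl against a hydroxyl on the core, and the data do not show which of these differences matters.

Still open, going by these compounds, is how the same change behaves with the shorter chain alongside the hydroxyl, or with the longer chain alongside the carbonyl. Also open, on these data alone, is what a still longer chain, such as 4-(diethylamino)butyl, or a larger amine, such as dipropylamino, would give.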